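Fluoro for methyl with every value at the limit

A few compounds are considered here, and "the series" means these few. Any claim that something is new, unique, unknown or untested is made for them only; others in the source may bear on it.

In a functional assay on A-375 cells (Homo sapiens) for antiproliferative activity, read by MTT assay, with a stated time of 72 h (on this read-out higher numbers stand for weaker inhibition and lower numbers for stronger inhibition), compound 1 `COc1cccc(N2C(=O)COc3ccc(-c4cnc(Cl)c(NS(=O)(=O)c5ccc(F)cc5)c4)cc32)c1` gives > 40000 nM as a limit of the assay. Compound 2 `O=C1COc2ccc(-c3cnc4ccccc4c3)cc2N1C1CCCCC1` gives > 40000 nM as a limit too. Compound 3 `Cc1ccc(N2C(=O)COc3ccc(-c4cnc5ccccc5c4)cc32)cc1` gives > 40000 nM as a limit as well. Among the measured compounds shown here, the series so far amounts to the limit of > 40000 nM in this assay, at which 3 of the 3 values shown sit, and no actual number.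

Compound 4 `O=C1COc2ccc(-c3cnc4ccccc4c3)cc2N1c1ccc(F)cc1` follows from compound 3 through fluoro in place of methyl on an aromatic carbon as fluoro in place of methyl on an aromatic carbon, para to a large group. Only a step that the two limits leave unreadable from compound 2 to compound 3 bears on this change and it gives no size to carry over. An expected a number no higher from compound 3 to compound 4 (the limit leaves the size open) in this assay stays within the scatter, in neither direction. Compound 4 is estimated at 40000 nM with an expected range of 15000 nM to 60000 nM and will probably be reported as a limit.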

Compound 4, half-maximal inhibitory concentration: > 40000 nM
Compound 4: no number, only a limit; the forecaster's own chance of this, stated with the estimate: 80%; the middle value sits exactly at the limit.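

Among the compounds shown here, no step among compound 2, compound 3 and compound 4 can be read, as all three values are limits: the limit of > 40000 nM in this assay, at which 4 of the 4 values shown sit. The compounds shown leave open whether fluoro in place of methyl changes antiproliferative activity at all.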